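Halogen swap on the nitrophenyl series: fluoro to chloro

The source may report more compounds than this note shows. Statements on the series, on what has been measured and on what is new or still open speak of the compounds shown alone.

Measured compounds in a functional assay on L1210 cells (Mus musculus) for cytotoxicity, with a stated time of 48 h; on this read-out higher numbers stand for weaker inhibition and lower numbers for stronger inhibition:
compound 1 `Cc1ccc(/C=C2\CCC/C(=C\c3ccc([N+](=O)[O-])cc3)C2=O)cc1` gives 8160 nM
compound 2 `COc1ccc(/C=C2\CCC/C(=C\c3ccccc3[N+](=O)[O-])C2=O)cc1` gives 42400 nM
compound 3 `O=C1/C(=C/c2ccc(F)cc2)CCC/C1=C\c1ccccc1[N+](=O)[O-]` gives 8400 nM

Compound 3 holds the second highest of the three numbers; compound 1 sits within the scatter of it, while compound 2 lies beyond the scatter above it, the difference being a 5.0-fold lower number from compound 2 to compound 3 (0.70 log units; beyond the scatter). Compound 4 `O=C1/C(=C/c2ccc(Cl)cc2)CCC/C1=C\c1ccccc1[N+](=O)[O-]` differs from compound 3 by chloro in place of fluoro on an aromatic carbon. For the measured compounds named here, no measured step exchanges one halogen for another; the only step touching this aromatic carbon, a 5.0-fold lower number from compound 2 to compound 3 (0.70 log units; beyond the scatter), concerns methoxy and is modest. The halogen swap is therefore expected to give a step no larger than the scatter, a 1.2-fold lower number from compound 3 to compound 4 (0.08 log units; within the scatter), with no clear direction. Compound 4 is estimated at 7000 nM, between 3000 nM and 18000 nM.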

Compound 4, half-maximal inhibitory concentration: 9380 nM
For compound 4 the middle estimate is 1.3-fold (0.13 log units) below the measured one; the measured number falls inside the stated range.
By their numbers in this assay, from the lowest: compounds 1, 3 and 4 (each within the scatter of the next); then compound 2.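

In this assay, for the compounds shown here, the first exchange of one halogen for another on this aromatic carbon, chloro in place of fluoro, gives a 1.1-fold higher number from compound 3 to compound 4 (0.05 log units; within the scatter) and so does not separate the two halogens. Chloro in place of methoxy gives a 4.5-fold lower number from compound 2 to compound 4 (0.66 log units; beyond the scatter) and thus matches the fluoro result, so the lower number relative to compound 2 is not particular to fluoro. Nothing available bears on the reason for this. Open, going by these compounds, is whether the higher number of compound 2 is particular to methoxy, and how a bromo, an amine or a carboxylic acid on this carbon would read.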